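Methyl in Place of Fluoro, Tried a Second Time

A few compounds are considered here, and "the series" means these few. Any claim that something is new, unique, unknown or untested is made for them only; others in the source may bear on it.

In a functional assay for agonist activity at thrombopoietin receptor (Homo sapiens) (on this read-out lower numbers stand for an effect already at smaller amounts and higher numbers for an effect only at larger amounts of compound), compound 1 `Nc1nc(-c2cccc(C(F)(F)F)c2F)c(F)s1` gives 700 nM. Compound 2 `Cc1sc(N)nc1-c1cccc(C(F)(F)F)c1F` differs from compound 1 by methyl in place of fluoro on an aromatic carbon, and in this assay compound 2 gives 540 nM; the step is a 1.3-fold lower number from compound 1 to compound 2 (0.11 log units; within the scatter). Compound 3 `Nc1nc(-c2ccc(F)c(C(F)(F)F)c2)c(F)s1` has the same atoms as compound 1, joined differently; the difference between the two cores is not broken down here. In this assay compound 3 gives 89 nM, the lowest number of the three, beyond the scatter from both others.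

Compound 4 `Cc1sc(N)nc1-c1ccc(F)c(C(F)(F)F)c1` has not yet been measured. It stands to compound 3 as compound 2 stands to compound 1: methyl in place of fluoro on an aromatic carbon. The surroundings of the place are described in the same words for both pairs, so this is the same change made on a different core.

Among the measured compounds shown here, the step from compound 3 to compound 4 in this assay is expected to be a 1.3-fold lower number from compound 3 to compound 4 (0.10 log units; within the scatter), which rests on the one earlier example of this change, a 1.3-fold lower number from compound 1 to compound 2 (0.11 log units; within the scatter), a step within the scatter. Compound 4 is therefore estimated at 70 nM, with a likely range from 30 nM to 200 nM.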

Compound 4, half-maximal effective concentration: 180 nM
For compound 4 the middle estimate is 2.6-fold (0.41 log units) below the measured one; low and high end bracket the measured number.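

In this assay, methyl in place of fluoro on the core of compound 3 gives a 2.0-fold higher number from compound 3 to compound 4 (0.31 log units; beyond the scatter), a modest step. Set beside the earlier example of this change, the new step cannot be told apart from it, although only the new step lies beyond the scatter on its own: the same change on two cores in this assay, a 1.3-fold lower number (0.11 log units; within the scatter) from compound 1 to compound 2 and a 2.0-fold higher number (0.31 log units; beyond the scatter) from compound 3 to compound 4, 2.6-fold (0.42 log units) apart, within the scatter of two such steps This shows no measurable dependence of the change on the core, but it does not show that the change carries over unaltered, as two pairs are too few to establish either, and they give no reason for the size of either step.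

The compounds shown hold only fluoro or methyl on the aromatic carbon next to the ring sulfur, so it remains open how chloro, ethyl or a nitrile would read out at that place on either core. All four compounds also keep the amino group, which leaves open what an acetamide or a methylamino group there would do.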